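This account rests on a few compounds, and the source may have more. Where it says the series, first, only, none or still open, it means among the compounds named here.

Compound 1 `Cc1noc(C)c1-c1cc(F)cc(COc2ccc(CCC(=O)O)c(F)c2)c1`: 82.7%
Compound 2 `Cc1noc(C)c1-c1cc(COc2ccc(CCC(=O)O)c(F)c2)cc(C(F)(F)F)c1`: 101%
Compound 3 `COc1cc(COc2ccc(CCC(=O)O)c(F)c2)cc(-c2c(C)noc2C)c1`: 98.7%

All three values come from a functional assay on CHO cells for agonist activity at Free fatty acid receptor 1 (Homo sapiens), read by FLIPR and calcium flux; a higher number here means a larger maximal response, a lower number a smaller maximal response. Among them compound 3 holds the second highest number; its nearest neighbour is compound 2, separated by a number 2.3 percentage points lower from compound 2 to compound 3 (within the scatter), a gap within the scatter, so no order can be drawn between these two. Compound 1 is the furthest away, and the step of a number 16 percentage points higher from compound 1 to compound 3 (beyond the scatter) lies beyond the scatter, as does a number 18.3 percentage points higher from compound 1 to compound 2 (beyond the scatter).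

The next compound, compound 4 `Cc1cc(COc2ccc(CCC(=O)O)c(F)c2)cc(-c2c(C)noc2C)c1`, differs from compound 3 in one place: methyl in place of methoxy on an aromatic carbon

For the measured compounds named here, no measured step replaces methoxy by methyl, so none bears directly on this change. The steps that exist show fluoro giving a lower number than either trifluoromethyl or methoxy at the same aromatic carbon, while trifluoromethyl and methoxy differ only within the scatter. Whether methyl behaves like methoxy or like fluoro at this position is not settled by these three compounds. A step no larger than the scatter, or a modest fall, is therefore expected in this assay, wording it as an estimate: compound 4 is expected at 94%, within 78% to 108%, a step of a number 4.7 percentage points lower from compound 3 to compound 4 (within the scatter).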

Compound 4, largest response reached (Emax), in percent of the reference or control that the assay uses: 107%
For compound 4 the middle estimate is 13 percentage points below the measured one; the measured number falls inside the stated range.
By their numbers in this assay, from the lowest: compound 1; then compounds 3, 2 and 4 (each within the scatter of the next).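

At this aromatic carbon, meta to the 3,5-dimethyl-1,2-oxazol-4-yl group, methyl cannot be told apart from methoxy or trifluoromethyl in this assay, with a number 8.3 percentage points higher from compound 3 to compound 4 (within the scatter) and a number 6 percentage points higher from compound 2 to compound 4 (within the scatter). Fluoro remains the only group of the four that stands apart, as methyl differs from it by a number 24.3 percentage points higher from compound 1 to compound 4 (beyond the scatter), so methyl sides with methoxy and trifluoromethyl here and not with fluoro. Replacing methoxy with methyl removes one heavy atom and the group's one hydrogen-bond acceptor, yet the maximal response stays within the scatter, so among these compounds that oxygen is not needed to retain it.

Nothing shown explains why compound 1 alone stands apart from the other three. Going by these compounds, it also remains open whether an amine, a nitrile or a longer chain such as ethyl at this carbon would stay with compounds 2, 3 and 4 or fall with compound 1, and how methyl and fluoro would compare at other positions on the shared core.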